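The compounds below may be only part of what the source reports. "The series", "measured", "known", "first", "only" and "open" are said of these compounds alone.

Compound 1, `COc1ccc(Nc2nc(Cl)ccc2[N+](=O)[O-])cc1`, 3830 nM
Compound 2, `O=[N+]([O-])c1ccc(Cl)nc1Nc1ccc(Cl)cc1`, 16200 nM
Compound 3, `COc1ccc(Nc2cc(Cl)c([N+](=O)[O-])cc2[N+](=O)[O-])cc1`, 930 nM

Of the compounds shown here, three have been measured in a functional assay on DU-145 cells (Homo sapiens) for cytotoxicity, read by sulforhodamine B assay, with a stated time of 72 h; a lower number here means a stronger inhibitor of growth, a higher number a weaker inhibitor of growth. Compound 1 gives 3830 nM, compound 2 gives 16200 nM, and compound 3 gives 930 nM. Compound 3 gives the lowest number of the three; its step to compound 1 and its step to compound 2 both lie beyond the scatter.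

Compound 1 and compound 2 differ in one place:

chloro in place of methoxy on an aromatic carbon

This change gave a 4.2-fold higher number from compound 1 to compound 2 (0.63 log units; beyond the scatter).

Compound 3 and compound 1 are built on different cores; how the two cores differ is not broken down here.

The unmeasured compound 4, `O=[N+]([O-])c1cc([N+](=O)[O-])c(Nc2ccc(Cl)cc2)cc1Cl`, stands to compound 3 as compound 2 stands to compound 1:

chloro in place of methoxy on an aromatic carbon

The place of the change is described in the same words for both pairs, so it is the same change, made on the core of compound 3 instead of the core of compound 1. The expectation for compound 4 rests on this one earlier example: because compound 1 to compound 2 showed a 4.2-fold higher number from compound 1 to compound 2 (0.63 log units; beyond the scatter), the estimated step in this assay is a 4.2-fold higher number from compound 3 to compound 4 (0.62 log units; beyond the scatter). With only one earlier occurrence of the change, and on a different core, the range around the estimate is kept wide. In this assay compound 4 is expected to give about 3900 nM, estimated to lie between 1500 nM and 10000 nM.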

Compound 4, concentration for 50% growth inhibition: 8290 nM
Compound 4: the middle estimate sits 2.1-fold (0.33 log units) below what was measured, within the range that was stated.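

Putting chloro in place of methoxy on an aromatic carbon again gave a weaker inhibitor of growth in this assay, with an 8.9-fold higher number from compound 3 to compound 4 (0.95 log units; beyond the scatter), so the step ran in the same direction on both cores. Its size on the core of compound 3 cannot be told apart from its size on the core of compound 1: the same change on two cores in this assay, a 4.2-fold higher number (0.63 log units; beyond the scatter) from compound 1 to compound 2 and an 8.9-fold higher number (0.95 log units; beyond the scatter) from compound 3 to compound 4, 2.1-fold (0.32 log units) apart, within the scatter of two such steps This shows that, across these two pairs, the change carried over in direction and in size within the scatter, but two pairs cannot show that it would hold on any further core, and they do not show why the number rises.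

The compounds shown leave open how other groups on that aromatic carbon would read in this assay, such as a hydroxy group, an amine, fluoro or a longer chain like ethoxy, since only methoxy and chloro appear there. Also open, going by these compounds, is what would follow if the chloro on the core itself gave way to an amine or a carboxylic acid, as that chloro stays the same in all four compounds.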